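Varying the amide group on a chalcone-type scaffold

The compounds below may be only part of what the source reports. "The series", "measured", "known", "first", "only" and "open" are said of these compounds alone.

Measured so far:
compound 1 `CCOC(=O)C(=O)Nc1cccc(C(=O)/C=C/c2ccc(O)c(OC)c2)c1`, 45%
compound 2 `COc1cc(/C=C/C(=O)c2cccc(NC(=O)c3cccs3)c2)ccc1O`, 80%
compound 3 `COc1cc(/C=C/C(=O)c2cccc(NC(=O)c3c(Cl)cccc3Cl)c2)ccc1O`, 88%

All three compounds share one core and differ only in the group attached to the carbonyl carbon of the amide. In a functional assay on HUVEC cells (Homo sapiens) for inhibition, tested at 5 ug/mL (a lower number here means a weaker effect, a higher number a stronger effect of the compound at the concentration tested), compound 1 gives 45%, compound 2 gives 80% and compound 3 gives 88%. Compound 3 therefore stands at the top of the three numbers, though its gap to compound 2 is within the scatter, so the two cannot be ordered; its gap to compound 1 is beyond the scatter.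

Compound 4 `COc1cc(/C=C/C(=O)c2cccc(NC(=O)c3ccc(Cl)cc3)c2)ccc1O` is not yet measured. It differs from compound 3 as follows: 4-chlorophenyl in place of 2,6-dichlorophenyl on a carbonyl carbon.

Two steps inform the expectation. Replacing the ethoxycarbonyl by an aromatic ring raised the read-out strongly, a number 35 percentage points higher from compound 1 to compound 2 (beyond the scatter) and a number 43 percentage points higher from compound 1 to compound 3 (beyond the scatter), while swapping one aromatic ring for another changed little, a number 8 percentage points higher from compound 2 to compound 3 (within the scatter). Since compound 4 keeps an aromatic ring on the carbonyl carbon, a step of about a number 6 percentage points lower from compound 3 to compound 4 (within the scatter) is expected. Compound 4 is therefore estimated at 82%, within 65% to 95%.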

Compound 4, a percentage reported as inhibition, at one concentration (the size of the read-out at that concentration, not a potency): 42%
Beside the measured number, compound 4's estimate is 40 percentage points above it, and the stated range ends above it.
By their numbers in this assay, from the lowest: compounds 4 and 1 (each within the scatter of the next); then compounds 2 and 3 (each within the scatter of the next).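

In this assay, an aromatic ring on the carbonyl carbon does not by itself give a high read-out, and the choice of ring matters much more than the first three compounds suggested: the change to 4-chlorophenyl gives a number 46 percentage points lower from compound 3 to compound 4 (beyond the scatter) and a number 38 percentage points lower from compound 2 to compound 4 (beyond the scatter). With a number 3 percentage points lower from compound 1 to compound 4 (within the scatter), the ring-bearing compound 4 cannot be told apart from the ethoxycarbonyl compound 1, so an aromatic ring in place of ethoxycarbonyl raises the number for compound 2 and compound 3 but not for compound 4. Nothing available explains the size of this drop.

The step from 2,6-dichlorophenyl to 4-chlorophenyl changes both the number of chlorine atoms and where they stand, and the compounds shown do not separate the two. Going by these compounds, how a plain phenyl ring would read on the same carbonyl carbon also remains open.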